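The source may report more compounds than this note shows. Statements on the series, on what has been measured and on what is new or still open speak of the compounds shown alone.

Measured so far in a functional assay on SW-620 cells (Homo sapiens) for antiproliferative activity, read by MTT assay, with a stated time of 24 h; on this read-out lower numbers stand for stronger inhibition and higher numbers for weaker inhibition:
- compound 1 `COc1ccc(C(=O)/C=C/c2ccc(Br)cc2)c2c1C=CC(C)(C)O2`: > 10000 nM (a limit)
- compound 2 `COc1ccc(C(=O)/C=C/c2ccc(N(C)C)cc2)c2c1C=CC(C)(C)O2`: 570 nM
- compound 3 `COc1ccc(C(=O)/C=C/c2ccc(N(c3ccccc3)c3ccccc3)cc2)c2c1C=CC(C)(C)O2`: > 10000 nM (a limit)

Among the measured compounds shown here, compound 2, at 570 nM, is the only compound here with an actual number. The other two values are limits, as shown by the limit of > 10000 nM in this assay, at which 2 of the 3 values shown sit.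

The next compound is compound 4 `COc1ccc(C(=O)/C=C/c2ccccc2)c2c1C=CC(C)(C)O2`, which differs from compound 2 as follows: hydrogen in place of dimethylamino on an aromatic carbon. In short, 4-(dimethylamino)phenyl becomes phenyl.

For the measured compounds named here, one measured step bears directly on this change: an at least 17-fold lower number from compound 1 to compound 2 (1.24 log units; beyond the scatter). It is large and replaces bromo with dimethylamino at the same place. Its size is only a bound, since compound 1 gives a limit. Removing dimethylamino is therefore expected to give a higher number in this assay, meaning weaker inhibition, and a result reported only as a limit would not be surprising. The expected change is a 12-fold higher number from compound 2 to compound 4 (1.09 log units; beyond the scatter). For compound 4 the estimated value is 7000 nM, with an expected range of 2000 nM to 20000 nM.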

Compound 4, half-maximal inhibitory concentration: > 10000 nM
Compound 4: no number, only a limit; the forecaster's own chance of this, stated with the estimate: 45%; at least 1.4-fold (0.15 log units) between middle value and limit.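

Removing dimethylamino from the aromatic carbon gives an at least 17-fold higher number from compound 2 to compound 4 (1.24 log units; beyond the scatter) in this assay, and this size is only a bound. Compound 4 gives a limit and not a number: the limit of > 10000 nM in this assay, at which 3 of the 4 values shown sit.

Among the four compounds, a number appears only with 4-(dimethylamino)phenyl, while the phenyl of compound 4, the bromo of compound 1 and the diphenylamino of compound 3 all stay at the limit, so the step between compound 1 and compound 4 cannot be read.

From the compounds shown here alone, whether a smaller amine such as amino or methylamino, or a larger one such as diethylamino or pyrrolidinyl, also gives a number at this place remains open. The limits also leave open how compound 1, compound 3 and compound 4 rank against one another.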